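This account rests on a few compounds, and the source may have more. Where it says the series, first, only, none or still open, it means among the compounds named here.

Measured so far in a functional assay on A549 cells (Homo sapiens) for antiproliferative activity, read by CCK-8 assay, with a stated time of 72 h; a higher number here means a weaker inhibitor, a lower number a stronger inhibitor:
compound 1 `Cc1ccc(C(=O)Nc2cccc(-c3oc4cc(-c5ccc(F)cc5)ccc4c(=O)c3O)c2)cc1` gives 6910 nM
compound 2 `O=C(Nc1cccc(-c2oc3cc(-c4ccc(F)cc4)ccc3c(=O)c2O)c1)c1ccc(C(F)(F)F)cc1` gives 19400 nM
compound 3 `O=C(Nc1cccc(-c2oc3cc(-c4ccc(F)cc4)ccc3c(=O)c2O)c1)c1cccc(F)c1` gives 15400 nM

Compound 2 has the highest number of the three, with a step of a 2.8-fold higher number from compound 1 to compound 2 (0.45 log units; beyond the scatter) that stands beyond the scatter, while a 1.3-fold lower number from compound 2 to compound 3 (0.10 log units; within the scatter) keeps compound 3 within the scatter of compound 2. The next compound, compound 4 `COc1ccc(C(=O)Nc2cccc(-c3oc4cc(-c5ccc(F)cc5)ccc4c(=O)c3O)c2)c(F)c1`, differs from compound 2 by 2-fluoro-4-methoxyphenyl in place of 4-(trifluoromethyl)phenyl on a carbonyl carbon. Among the compounds with values here, the steps that bear on it are a 2.8-fold higher number from compound 1 to compound 2 (0.45 log units; beyond the scatter) and a 2.2-fold higher number from compound 1 to compound 3 (0.35 log units; beyond the scatter), both modest and both leaving the 4-methylphenyl amide of compound 1 with the lowest number. A modest lower number than compound 2 is therefore expected, a 2.0-fold lower number from compound 2 to compound 4 (0.31 log units; beyond the scatter). Compound 4 is estimated at 9500 nM, with a range of 4000 nM to 22000 nM.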

Compound 4, half-maximal inhibitory concentration: 40000 nM
For compound 4 the middle estimate is 4.2-fold (0.62 log units) below the measured one, outside the stated range (above it).
By their numbers in this assay, from the lowest: compound 1; then compounds 3 and 2 (each within the scatter of the next); then compound 4.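

On the carbonyl carbon, 2-fluoro-4-methoxyphenyl gives the weakest compound of the four, with a 2.1-fold higher number from compound 2 to compound 4 (0.31 log units; beyond the scatter) and a 2.6-fold higher number from compound 3 to compound 4 (0.41 log units; beyond the scatter) and a 5.8-fold higher number from compound 1 to compound 4 (0.76 log units; beyond the scatter) all beyond the scatter. Within the data shown here, the range at this position therefore widens, and the only amide aryl group here with an oxygen sits at the weak end, with 4-methylphenyl still at the strong end. Nothing available explains this loss of activity.

The compounds shown do not separate the fluorine of compound 4 from its methoxy. From the compounds shown here alone, whether an amine or a carboxylic acid on this phenyl ring would bring the number below that of compound 1 remains open.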